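Removing the Acetyl Group from Compound 1

A few compounds are considered here, and "the series" means these few. Any claim that something is new, unique, unknown or untested is made for them only; others in the source may bear on it.

In a functional assay on SW480 cells (Homo sapiens) for cytotoxicity, read by sulforhodamine B assay, with a stated time of 48 h (a higher number here means a weaker inhibitor, a lower number a stronger inhibitor), compound 1 (`COc1ccc(/C=C/C(=O)c2ccc(NC(C)=O)c(-c3ccc(F)cc3)c2)cc1OC`) gives 5350 nM. Two other compounds offer a comparison. Compound 3 (`COc1ccc(/C=C/C(=O)c2cccc(-c3cccc(F)c3)c2)cc1OC`) gives 2970 nM, which lies within the usual scatter of compound 1, so the two numbers cannot be told apart. Compound 2 (`COc1ccccc1/C=C/C(=O)c1cccc(-c2cccc(F)c2)c1`) gives 16600 nM, and this number is higher than that of compound 1 by a gap beyond the scatter, which marks compound 2 as the weaker inhibitor of that pair.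

Compound 4 (`COc1ccc(/C=C/C(=O)c2ccc(N)c(-c3ccc(F)cc3)c2)cc1OC`) has not yet been measured. It differs from compound 1 in one place: hydrogen in place of acetyl on a nitrogen on an aromatic ring. Hydrogen stands in place of acetyl on a nitrogen on an aromatic ring, so acetamido becomes amino. Going by the values given here, no measured pair shows this change, so the data give no direct guide to its size in this assay. Compound 3 carries no acetamido group, yet its 2970 nM stays within the scatter of compound 1, which suggests that a large step is unlikely. The expected outcome is a 1.5-fold lower number from compound 1 to compound 4 (0.18 log units; within the scatter), a small move towards a lower number that stays within the scatter. For compound 4 the estimated value is 3500 nM, with an expected range of 1200 nM to 10000 nM.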

Compound 4, half-maximal inhibitory concentration: 6640 nM
The estimate for compound 4 lay 1.9-fold (0.28 log units) below the measured number, within the range that was stated.
By their numbers in this assay, from the lowest: compounds 3, 1 and 4 (each within the scatter of the next, the first and the last beyond it); then compound 2.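

Removing the acetyl from the nitrogen on the aromatic ring gives, in this assay, a 1.2-fold higher number from compound 1 to compound 4 (0.09 log units; within the scatter), so the two compounds cannot be told apart. Going by these compounds alone, this is the first direct reading of the change from acetamido to amino on the core of compound 1, and it shows that in this one pair the acetyl, with its 3 heavy atoms, can be replaced by hydrogen without a difference this read-out can resolve, something the earlier compounds, which differ from compound 1 in more than one place, could not show. Nothing available here offers an explanation for this result.

The compounds shown leave open how a methyl group, a longer acyl chain or a methanesulfonyl group on this nitrogen would read in this assay, since only acetyl and hydrogen appear there. They also leave open whether the change from acetamido to amino would read the same way on another core, such as that of compound 2, as this single pair cannot establish a general pattern.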